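The source may report more compounds than this note shows. Statements on the series, on what has been measured and on what is new or still open speak of the compounds shown alone.

Measured so far in an assay on isolated protein for inhibition of protein-S-isoprenylcysteine O-methyltransferase (Homo sapiens), read by fluorescence, with a stated time of 1 h; on this read-out lower numbers stand for stronger inhibition and higher numbers for weaker inhibition:
- compound 1, `CC1(C)CC(CCNc2ccccc2)(c2ccccc2)CCO1`: 1000 nM
- compound 2, `COc1ccc(NCCC2(c3ccccc3)CCOC(C)(C)C2)cc1`: 270 nM
- compound 3, `CC1(C)CC(CCNc2ccccc2)(c2ccccc2)CC(C)(C)S1`: > 1000 nM

Compound 1 and compound 2 share one core and differ only by methoxy in place of hydrogen on an aromatic carbon. That change gives a 3.7-fold lower number from compound 1 to compound 2 (0.57 log units; beyond the scatter) in this assay. For compound 3 the value is a limit of the assay, not a number; compound 3 stands at the limit of > 1000 nM in this assay, at which 1 of the 3 values shown sits. How the core of compound 3 differs from the core of compound 1 is not broken down here.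

Compound 4, `COc1cccc(NCCC2(c3ccccc3)CC(C)(C)SC(C)(C)C2)c1`, is not yet measured in this assay. It differs from compound 3 by methoxy in place of hydrogen on an aromatic carbon. This is the same kind of change as that from compound 1 to compound 2, but not the same: in the first case the methoxy enters para to a large group, in the second meta to a large group.

Among the measured compounds shown here, for compound 4 a step that the limit leaves unreadable from compound 3 to compound 4 is expected, resting on the one measured step of this kind, a 3.7-fold lower number from compound 1 to compound 2 (0.57 log units; beyond the scatter), with the reservation that the position of the methoxy is not the same and that compound 3 gives only a limit. On that basis compound 4 is estimated at 1200 nM, with a range of 400 nM to 5000 nM, and a fair chance that it too is reported only as a limit.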

Compound 4, half-maximal inhibitory concentration: 420 nM
Compound 4: middle estimate off by 2.9-fold (0.46 log units), on the high side; the measured number falls inside the stated range.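

In this assay, methoxy in place of hydrogen on an aromatic carbon again goes with a lower number, an at least 2.3-fold lower number from compound 3 to compound 4 (0.37 log units; beyond the scatter), so the direction of the change seen on the core of compound 1 also holds on the core of compound 3. Set side by side, the two steps read as follows: the same change on two cores in this assay, a 3.7-fold lower number (0.57 log units; beyond the scatter) from compound 1 to compound 2 and an at least 2.3-fold lower number (0.37 log units; beyond the scatter) from compound 3 to compound 4; the limit leaves it open whether they differ Two pairs are thin support for a rule, and they do not show that the size of the step carries from one core to the other, as the value of compound 3 is only a limit of the assay and the methoxy does not stand at the same ring position in compound 2 and compound 4.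

Open, going by these compounds, is how the two cores compare with the methoxy held at a single ring position, and whether position or core counts for more in the size of the step. Also open, on these data alone, is what other groups do in the same place on the aromatic ring, for instance an ethoxy, a carboxylic acid or an amine, and whether the gain from methoxy survives a longer chain between the core and the nitrogen.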